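The source may report more compounds than this note shows. Statements on the series, on what has been measured and on what is new or still open speak of the compounds shown alone.

Measured compounds in a functional assay on HeLa cells (Homo sapiens) for cytotoxicity, read by MTT assay, with a stated time of 48 h; a lower number here means a stronger inhibitor, a higher number a weaker inhibitor:
compound 1 `CCOC(=O)c1c(-c2cc3ccccc3oc2=O)nn(-c2ccccc2)c1C(=O)OCC` — 100000 nM
compound 2 `CCOC(=O)c1c(-c2cc3ccccc3oc2=O)nn(-c2ccc(C)c(C)c2)c1C(=O)OCC` — 50000 nM
compound 3 `CCOC(=O)c1c(-c2cc3ccccc3oc2=O)nn(-c2cccc(Cl)c2)c1C(=O)OCC` — 22000 nM

Compound 3 stands at the lowest number of the three. The nearest is compound 2, a 2.3-fold lower number from compound 2 to compound 3 (0.36 log units; beyond the scatter); the furthest is compound 1, a 4.5-fold lower number from compound 1 to compound 3 (0.66 log units; beyond the scatter). The step from compound 1 to compound 2, a 2.0-fold lower number from compound 1 to compound 2 (0.30 log units; within the scatter), lies within the scatter.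

Compound 4 `CCOC(=O)c1c(-c2cc3ccccc3oc2=O)nn(-c2cccc(F)c2)c1C(=O)OCC` is not yet measured. Its difference from compound 3 is fluoro in place of chloro on an aromatic carbon. The change sits on an aromatic carbon of a six-membered aromatic ring of carbon only, meta to a large group.

Among the measured compounds shown here, only one measured step touches that carbon: from compound 1 to compound 3, a 4.5-fold lower number from compound 1 to compound 3 (0.66 log units; beyond the scatter), chloro in place of hydrogen. No measured step swaps one halogen for another, so the size of a fluoro-for-chloro step is not directly shown. With fluoro taking the place of chloro, a modest rise in the number toward that of compound 1 is expected rather than a fall; the expected step is a 1.8-fold higher number from compound 3 to compound 4 (0.26 log units; within the scatter). Compound 4 is estimated at 40000 nM, with a range from 15000 nM to 110000 nM.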

Compound 4, half-maximal inhibitory concentration: 68000 nM
Compound 4: middle estimate off by 1.7-fold (0.23 log units), on the low side; measured number inside the range.
By their numbers in this assay, from the lowest: compound 3; then compounds 2, 4 and 1 (each within the scatter of the next).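

In this assay this carbon now separates two halogens (a 3.1-fold higher number from compound 3 to compound 4 (0.49 log units; beyond the scatter)), so the gain seen with chloro does not carry over to fluoro. Fluoro in place of hydrogen stays within the scatter (a 1.5-fold lower number from compound 1 to compound 4 (0.17 log units; within the scatter)), as does 3-fluorophenyl in place of 3,4-dimethylphenyl on the aromatic nitrogen (a 1.4-fold higher number from compound 2 to compound 4 (0.13 log units; within the scatter)), which leaves chloro as the only change here with a step beyond the scatter from the unsubstituted phenyl. No measurement at hand explains the gap between chloro and fluoro at this carbon.

Open, on these data alone, is whether bromo or iodo at this carbon would follow chloro or fluoro, and whether a methoxy group or an amine there would move the number at all. Also open, as far as these compounds go, is whether chloro gives a similar step on the other carbons of the phenyl ring.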